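The source may hold more compounds than are shown below. What is called first, only, known or untested is meant among the compounds shown, and "the series" means these compounds.

Compound 1, `CC1CCN(c2nc(C(F)(F)F)ccc2CNC(=O)C(C)c2ccc3c(c2)CCC3)CC1`, gives 57.4 nM in an assay on CHO-K1 cells for antagonist activity at transient receptor potential cation channel subfamily V member 1 (Homo sapiens), read by FLIPR; on this read-out higher numbers stand for weaker inhibition and lower numbers for stronger inhibition.
Compound 2, `CC(C(=O)NCc1cc(C(F)(F)F)nn1-c1ccc(Cl)cc1)c1ccc2c(c1)CCC2`, gives 45 nM in this assay.

Only these two compounds have been measured so far. Compound 2 holds the lower of the two numbers, yet its distance from compound 1 lies within the usual scatter of repeated measurements, so the two cannot be ranked against each other; both sit in the same region of inhibition.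

Compound 3, `CC(C(=O)NCc1cc(C(F)(F)F)nn1-c1ccc(OC(F)(F)F)cc1)c1ccc2c(c1)CCC2`, has not yet been measured. It differs from compound 2 in a single place: trifluoromethoxy in place of chloro on an aromatic carbon. Going by the values given here, nothing else in the molecule changes, and no pair of measured compounds shows this exchange, so there is no measured step to lean on. The shared core of compounds 2 and 3 carries the trifluoromethyl group, the amide and the bicyclic tail unchanged.

For compound 3 the step of a 1.1-fold lower number from compound 2 to compound 3 (0.05 log units; within the scatter) is expected to be small, within the scatter, with no clear direction. Compound 3 is therefore estimated to give 40 nM in this assay, with a range from 15 nM to 120 nM.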

Compound 3, inhibition constant: 51.6 nM
Compound 3: the middle estimate sits 1.3-fold (0.11 log units) below what was measured; the range from low to high includes it.
By their numbers in this assay, from the lowest: compounds 2, 3 and 1 (each within the scatter of the next).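

Putting trifluoromethoxy in place of chloro on this aromatic carbon, para to a large group, gives a 1.1-fold higher number from compound 2 to compound 3 (0.06 log units; within the scatter) in this assay, so compound 2 and compound 3 cannot be told apart on this read-out. Going by these compounds alone, this is the first measured step at this position, and it shows that the 4-chlorophenyl and 4-(trifluoromethoxy)phenyl forms of this shared core read alike, even though trifluoromethoxy is the larger group by heavy atoms and, unlike chloro, counts as a hydrogen-bond acceptor. Nothing measured here explains why the two forms read alike, so the result stands as an observation without a known cause.

With only this one exchange at this position, the compounds shown say nothing about how far the tolerance seen here extends, since a single pair cannot show whether other groups on this carbon, such as a plain hydrogen, a methyl, a nitrile, an amine or a carboxylic acid, would also fall in the same region. They also leave open whether the same exchange would read alike on a different core, such as that of compound 1.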